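The source may report more compounds than this note shows. Statements on the series, on what has been measured and on what is new or still open speak of the compounds shown alone.

Values in a functional assay on HCT-116 cells (Homo sapiens) for antiproliferative activity, read by sulforhodamine B assay, with a stated time of 72 h (on this read-out higher numbers stand for weaker inhibition and lower numbers for stronger inhibition), so far:
Compound 1 (`COc1ncc(-c2ccc3ncc(NCC4CCCCC4)c(OC)c3c2)cc1NS(=O)(=O)c1ccc(F)cc1F`) - 13600 nM
Compound 2 (`COc1ccc(CNc2cnc3ccc(-c4cnc(OC)c(NS(=O)(=O)c5ccc(F)cc5F)c4)cc3c2OC)cc1`) - 10200 nM

Compound 2 stands (10200 nM) within the scatter of compound 1. Compound 3 (`COc1ncc(-c2ccc3ncc(NCC4CCN(C(C)=O)CC4)c(OC)c3c2)cc1NS(=O)(=O)c1ccc(F)cc1F`) differs from compound 2 by one change (1-acetylpiperidin-4-yl in place of 4-methoxyphenyl on a saturated chain carbon bound to a nitrogen on an aromatic ring) on a saturated chain carbon bound to a nitrogen on an aromatic ring. Going by the values given here, the one measured step at that place (a 1.3-fold lower number from compound 1 to compound 2 (0.12 log units; within the scatter)) stayed within the scatter, so no step beyond the scatter is expected in this assay for this change. The expected step (a 1.0-fold lower number from compound 2 to compound 3 (0.01 log units; within the scatter)) is accordingly small. Compound 3 is estimated at 10000 nM (expected range 3500 nM to 30000 nM).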

Compound 3, half-maximal inhibitory concentration: 1930 nM
Estimate against measurement, compound 3: 5.2-fold (0.71 log units) above; the measured number lies below the stated range.
By their numbers in this assay, from the lowest: compound 3; then compounds 2 and 1 (each within the scatter of the next).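

In this assay, 1-acetylpiperidin-4-yl on the saturated chain carbon bound to a nitrogen on an aromatic ring moves the number beyond the scatter (a 5.3-fold lower number from compound 2 to compound 3 (0.72 log units; beyond the scatter) and a 7.0-fold lower number from compound 1 to compound 3 (0.85 log units; beyond the scatter)). Exchanging cyclohexyl for 4-methoxyphenyl at this place had not done so, which shows that the position is not indifferent to the group it carries. No available evidence bears on the reason for this difference.

The compounds shown leave open whether the lower number depends on the acetyl group or on the piperidine ring. A piperidine with its ring amine free, or a morpholine ring, would help separate the two.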